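The source may report more compounds than this note shows. Statements on the series, on what has been measured and on what is new or still open speak of the compounds shown alone.

Working notes on the series.

Compound 2 `CCn1c(=O)/c(=C2\Sc3ccc(C)cc3N2C)s/c1=C\c1ccncc1Nc1ccccc1C` and compound 1 `CCn1c(=O)/c(=C2\Sc3ccc(C)cc3N2C)s/c1=C\c1ccncc1Nc1ccccc1Cl` share one core and differ only at the arylamino end. In a functional assay on PC-3 cells (Homo sapiens) for inhibition (on this read-out lower numbers stand for stronger inhibition and higher numbers for weaker inhibition), compound 2 gives 330 nM. The change chloro in place of methyl on an aromatic carbon leads to compound 1, which in this assay gives 500 nM; the step is a 1.5-fold higher number from compound 2 to compound 1 (0.18 log units; within the scatter).

Compound 3 `CCn1c(=O)/c(=C2\Sc3cc(F)ccc3N2C)s/c1=C\c1ccncc1Nc1ccccc1C` has a different core and carries the (2-methylphenyl)amino end of compound 2. In this assay compound 3 gives 2300 nM, the highest of the three numbers, and its gaps to compound 1 and to compound 2 both lie beyond the scatter. The difference between the core of compound 3 and the core of compound 2 is not broken down here.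

Compound 4 `CCn1c(=O)/c(=C2\Sc3cc(F)ccc3N2C)s/c1=C\c1ccncc1Nc1ccccc1Cl` is not yet measured. It keeps the core of compound 3 and is related to it by chloro in place of methyl on an aromatic carbon. Going by the values given here, this is the same change as the one from compound 2 to compound 1: the place reads the same word for word in both cases, on an aromatic carbon of a six-membered aromatic ring of carbon only. The change occurs twice in all among these compounds, and only one of its occurrences has been measured, on the other core.

Among the compounds with values here, the step from compound 3 to compound 4 is expected to be a 1.4-fold higher number from compound 3 to compound 4 (0.14 log units; within the scatter), because the only measured instance of this change is a 1.5-fold higher number from compound 2 to compound 1 (0.18 log units; within the scatter), a step within the scatter, so little movement is expected. Compound 4 is accordingly estimated to give 3200 nM in this assay, with a likely range from 1400 nM to 7500 nM; the transfer of a single small step to a second core leaves the range wide.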

Compound 4, half-maximal inhibitory concentration: 1200 nM
Compound 4: the middle estimate sits 2.7-fold (0.43 log units) above what was measured, outside the stated range (below it).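

On the core of compound 3, the change of methyl to chloro gives a 1.9-fold lower number from compound 3 to compound 4 (0.28 log units; within the scatter) in this assay, so this step alone shows no clear effect of the change. Its gap to the earlier step is larger than repeated measurement would readily explain, so in this pair of cores the step on one core does not serve as a fixed increment for the other: the same change on two cores in this assay, a 1.5-fold higher number (0.18 log units; within the scatter) from compound 2 to compound 1 and a 1.9-fold lower number (0.28 log units; within the scatter) from compound 3 to compound 4, 2.9-fold (0.46 log units) apart, beyond the scatter of two such steps This shows only that the effect of this change depends on the core to a degree that can be detected across the two pairs; it does not show that chloro favours one core and methyl the other, since each step on its own lies within the scatter, and it gives no reason for the gap.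

Going by these compounds, it remains open which part of the difference between the core of compound 2 and the core of compound 3 goes with the gap, and whether a third core would follow either step. Also open, on these data alone, is how other groups at this place on the ring, such as fluoro, methoxy or an amine, would behave on either core.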